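The source may report more compounds than this note shows. Statements on the series, on what has been measured and on what is new or still open speak of the compounds shown alone.

Working notes on the series. In a functional assay on HEK293 cells for agonist activity at growth hormone secretagogue receptor type 1 (Homo sapiens), read by HTRF and inositol phosphate accumulation, with a stated time of 90 min, in the presence of a further agent that is not named here (a lower number here means a smaller maximal response, a higher number a larger maximal response), compound 1 `Cc1ccc2[nH]c(C(=O)N[C@H]3CN(S(=O)(=O)c4ccccc4)C[C@@H]3C(=O)NCCN(C)C)cc2c1` gives 93%. Compound 2 `Cc1ccc2[nH]c(C(=O)N[C@H]3CN(S(=O)(=O)c4ccccc4)C[C@H]3C(=O)NCCN(C)C)cc2c1` gives 72% in this assay; the step of a number 21 percentage points lower from compound 1 to compound 2 (beyond the scatter) rests on (the fact that compounds 1 and 2 differ only in the configuration as drawn). Compound 3 `Cc1ccc2[nH]c(C(=O)N[C@H]3CN(S(=O)(=O)c4ccccc4)C[C@@H]3C(=O)NC[C@H]3CCCN3)cc2c1` gives 94% in this assay. The step of a number 1 percentage points higher from compound 1 to compound 3 (within the scatter) shows that pyrrolidin-2-yl in place of (dimethylamino)methyl leaves the maximal response unchanged. Compound 3 therefore sits with compound 1 within the scatter, and clearly above compound 2.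

Compound 4 `Cc1ccc2[nH]c(C(=O)N[C@H]3CN(S(=O)(=O)c4ccccc4)C[C@@H]3C(=O)NC[C@H]3CCCN3C)cc2c1` is not yet measured in this assay. Its difference from compound 3 is methyl in place of hydrogen on an amine nitrogen in a ring. Going by the values given here, no measured step exchanges methyl for hydrogen on an amine nitrogen; the nearest evidence is that compound 1, with (dimethylamino)methyl, and compound 3, with pyrrolidin-2-yl, give maximal responses within the scatter of each other, so the methylation state of the amine appears not to move the read-out across these two. Compound 4 is thus expected to show no step beyond the scatter, a number 2 percentage points lower from compound 3 to compound 4 (within the scatter). The estimate for compound 4 is 92%, from 78% to 100%.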

Compound 4, largest response reached (Emax), in percent of the reference or control that the assay uses: 98%
Compound 4: middle estimate off by 6 percentage points, on the low side; low and high end bracket the measured number.
By their numbers in this assay, from the lowest: compound 2; then compounds 1, 3 and 4 (each within the scatter of the next).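

In this assay, the exchange of hydrogen for methyl on the amine nitrogen of the five-membered ring can now be read directly: with a number 4 percentage points higher from compound 3 to compound 4 (within the scatter), this nitrogen takes the added methyl with no change in maximal response that stands out from the scatter. The wider exchange of (dimethylamino)methyl for 1-methylpyrrolidin-2-yl gives a number 5 percentage points higher from compound 1 to compound 4 (within the scatter), so compounds 1, 3 and 4, which share the same drawn configuration on the central ring, cannot be separated by this read-out. Nothing given here bears on why this methyl leaves the maximal response in place.

On these data alone, it remains open whether a larger group on this nitrogen, such as ethyl, benzyl or acetyl, would be tolerated as well. As far as these compounds go, it is also open whether a side chain ending in a hydroxyl group or a carboxylic acid instead of an amine would keep this response.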